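This account rests on a few compounds, and the source may have more. Where it says the series, first, only, none or still open, it means among the compounds named here.

Compound 1 `COc1nc(N2CCN(C)CC2)nc(OC)c1Sc1cccc(NC(=O)c2ccccc2)c1` and compound 3 `COc1nc(N2CCN(C)CC2)ccc1Sc1cccc(NC(=O)c2ccccc2)c1` carry the same benzamido side chain but sit on different cores; the difference between the two cores is not broken down here. In a functional assay on Kasumi 1 cells (Homo sapiens) for cytotoxicity, read by resazurin assay, with a stated time of 72 h (a higher number here means a weaker inhibitor, a lower number a stronger inhibitor), compound 1 gives 8100 nM, and compound 3 gives 4700 nM. These two numbers lie within the usual scatter of each other, so no order is drawn between them. Compound 2 `COc1nc(N2CCN(C)CC2)nc(OC)c1Sc1cccc(NC(=O)CN)c1` is related to compound 1 by the change (aminomethyl in place of phenyl on a carbonyl carbon). In this assay compound 2 gives 22500 nM, which amounts to a 2.8-fold higher number from compound 1 to compound 2 (0.44 log units; beyond the scatter). Compound 4 `COc1nc(N2CCN(C)CC2)ccc1Sc1cccc(NC(=O)CN)c1` has not yet been measured. It stands to compound 3 exactly as compound 2 stands to compound 1, through the change (aminomethyl in place of phenyl on a carbonyl carbon), made at the same place and therefore the same change. For the measured compounds named here, the pair of compound 1 and compound 2 is the only measured instance of this change among the four compounds, and the expectation for compound 4 rests on it alone, since the step of a 2.8-fold higher number from compound 1 to compound 2 (0.44 log units; beyond the scatter) is the only guide to how this side chain behaves in this assay. Compound 4 is expected to show a 2.8-fold higher number from compound 3 to compound 4 (0.44 log units; beyond the scatter). Compound 4 is therefore estimated at 13000 nM in this assay. Going by the values given here, with only one prior instance to lean on, the likely range for compound 4 is taken broadly, from 6000 nM to 28000 nM.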

Compound 4, half-maximal inhibitory concentration: 19100 nM
Compound 4: the middle estimate sits 1.5-fold (0.17 log units) below what was measured, within the range that was stated.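

In this assay, putting aminomethyl in place of phenyl on the carbonyl carbon on the core of compound 3 again gives a weaker inhibitor, with a 4.1-fold higher number from compound 3 to compound 4 (0.61 log units; beyond the scatter). Set beside the earlier step on the core of compound 1, the change keeps its direction on both cores, and the two steps cannot be told apart in size: the same change on two cores in this assay, a 2.8-fold higher number (0.44 log units; beyond the scatter) from compound 1 to compound 2 and a 4.1-fold higher number (0.61 log units; beyond the scatter) from compound 3 to compound 4, 1.5-fold (0.17 log units) apart, within the scatter of two such steps This shows that, for these two cores and this one cell assay, the step measured on one core was a fair guide to the step on the other, but two pairs do not establish that it would carry to any further core, and they give no ground for calling either core the more sensitive to the change.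

The compounds shown leave open whether the higher number follows the loss of the phenyl ring or the arrival of the amine, since the change does both at once; a methyl group, a longer aminoethyl chain or a dimethylaminomethyl group on the same carbonyl carbon would bear on that. They also leave open whether a phenyl ring carrying an amine would behave like phenyl or like aminomethyl on either core.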